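Acetyl in place of methyl on compound 2

A few compounds are considered here, and "the series" means these few. Any claim that something is new, unique, unknown or untested is made for them only; others in the source may bear on it.

Compound 1 `CC(C)CCn1c(Cn2c(=O)n(C(C)C)c3ccccc32)nc2c(CN)cccc21` – 7000 nM
Compound 2 `CNCc1ccc2c(c1)nc(Cn1c(=O)n(C(C)C)c3ccccc31)n2CCC(C)C` – 1480 nM

In an ADME assay on HEp-2 cells (Homo sapiens) for cytotoxicity (a lower number here means that less compound is tolerated, a higher number that more compound is tolerated), compound 2 stands lowest of the two measured compounds at 1480 nM, and the gap to compound 1 at 7000 nM lies beyond the scatter. The two differ in more than one place, so this gap says nothing about any single change.

Compound 3 `CC(=O)NCc1ccc2c(c1)nc(Cn1c(=O)n(C(C)C)c3ccccc31)n2CCC(C)C` is still to be measured. It carries acetyl in place of methyl on an amine nitrogen, turning methylamino into acetamido. For the measured compounds named here, no measured pair shows this change, so its size cannot be read from the data, and the expectation is a judgement on the change alone. A moderate rise in this assay is expected, meaning more compound tolerated, though a result within the scatter would be no surprise. The expected step of a 4.7-fold higher number from compound 2 to compound 3 (0.67 log units; beyond the scatter) is therefore upward and uncertain. The estimated value for compound 3 is 7000 nM, with an expected range from 2500 nM to 25000 nM.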

Compound 3, half-maximal cytotoxic concentration: 178000 nM
Beside the measured number, compound 3's estimate is 25-fold (1.41 log units) below it; the whole stated range lies below it.
By their numbers in this assay, from the lowest: compound 2; then compound 1; then compound 3.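

Acetyl in place of methyl on an amine nitrogen, with its saturated chain carbon unchanged, is the first change in this set that can be read in one place, and in this assay it gives a 120-fold higher number from compound 2 to compound 3 (2.08 log units; beyond the scatter). This shows that the group on this nitrogen has a large bearing on the concentration at which the cells show half-maximal cytotoxicity: turning (methylamino)methyl into acetamidomethyl alone moves the number far beyond the scatter. No available evidence accounts for a step of this size.

The compounds shown leave open whether this rise is particular to acetyl or would also appear with other groups on this nitrogen, such as a formyl group, a methanesulfonyl group, a longer acyl chain or a plain primary amine. They also leave open whether acetyl on the amine nitrogen of compound 1 would bring a step of similar size, so this single pair cannot yet be taken as a pattern for the series.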